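The compounds below may be only part of what the source reports. "The series", "measured", "known", "first", "only" and "open" are said of these compounds alone.

Measured so far in an assay on HeLa cells for inhibition of Indoleamine 2,3-dioxygenase 1 (Homo sapiens), with stated times of 1 h and 18 h; on this read-out lower numbers stand for stronger inhibition and higher numbers for weaker inhibition:
compound 1 `Cc1ccc(NC(=O)Nc2cc(-c3ccccc3C(=O)O)ccc2N(C)c2ccccc2C(C)(C)C)cc1`: > 1000 nM
compound 2 `CCCCN(CCCC)c1ccc(-c2ccccc2C(=O)O)cc1NC(=O)Nc1ccc(C)cc1`: 45 nM

In this assay compound 1 gives only a limit, > 1000 nM. Going by the values given here, compound 2 gives 45 nM, the single number among the two values shown. The other value, that of compound 1, is a limit (the limit of > 1000 nM in this assay, at which 1 of the 2 values shown sits). Among the compounds with values here, the one step measured, an at least 22-fold lower number from compound 1 to compound 2 (1.34 log units; beyond the scatter), exchanged an amine bearing an aryl group for a dialkylamine and was large.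

Compound 3 `Cc1ccc(NC(=O)Nc2cc(-c3ccccc3C(=O)O)ccc2N(CC2CC2)CC2CC2)cc1` differs from compound 2 by bis(cyclopropylmethyl)amino in place of dibutylamino on an aromatic carbon. This is a change from one dialkylamine to another, so the large measured step gives no direct guide to its size; nothing in the two compounds shown speaks for a shift beyond the scatter. The step from compound 2 to compound 3 is therefore expected to be small, a 1.1-fold higher number from compound 2 to compound 3 (0.05 log units; within the scatter). For compound 3 the estimated value in this assay is 50 nM, with a range from 15 nM to 160 nM.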

Compound 3, half-maximal inhibitory concentration: 348 nM
Estimate against measurement, compound 3: 7.0-fold (0.84 log units) below, and the stated range ends below it.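

The position para to the 2-carboxyphenyl group responds to a change within the dialkylamines as well, not only to the loss of the aryl-bearing amine: this assay shows a 7.7-fold higher number from compound 2 to compound 3 (0.89 log units; beyond the scatter), although leaving and entering groups match in their counted heavy atoms, carbon and nitrogen. Bis(cyclopropylmethyl)amino still keeps part of the gain seen with dibutylamino, with an at least 2.8-fold lower number from compound 1 to compound 3 (0.45 log units; beyond the scatter). Compound 1 gives a limit, > 1000 nM, not a number.

The compounds shown give no cause for the difference between dibutylamino and bis(cyclopropylmethyl)amino. Open, as far as these compounds go, is whether the two three-membered rings account for it, which a butyl(cyclopropylmethyl)amino group or a dipropylamino group at the same place could help to separate.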